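Benzyl for tert-butyl on an ester with no readable potency

The source may report more compounds than this note shows. Statements on the series, on what has been measured and on what is new or still open speak of the compounds shown alone.

In a functional assay on Jurkat cells (Homo sapiens) for cytotoxicity, with a stated time of 72 h (on this read-out higher numbers stand for an effect only at larger amounts of compound and lower numbers for an effect already at smaller amounts), compound 1 (`C=C[C@@](C)(/C=C/c1ccc(O)c(/C=C/C(=O)OCc2ccccc2)c1)CCC=C(C)C`) gives > 49000 nM as a limit. Compound 2 (`CCOC(=O)/C(C)=C/c1cc(/C=C/[C@](C)(/C=C/c2ccc(OC)cc2)CCC=C(C)C)ccc1O`) gives > 49000 nM, also a limit. Compound 3 (`COc1ccc(/C=C/[C@@](C)(/C=C/c2ccc(O)c(/C=C/C(=O)OC(C)(C)C)c2)CCC=C(C)C)cc1`) gives > 49000 nM, again only a limit, and so has no number to stand on. The series shows the limit of > 49000 nM in this assay, at which 3 of the 3 values shown sit, and nothing else. Within the data shown here, the one measured step is a step that the two limits leave unreadable from compound 2 to compound 3 and offers no size to carry over. Compound 4 (`COc1ccc(/C=C/[C@@](C)(/C=C/c2ccc(O)c(/C=C/C(=O)OCc3ccccc3)c2)CCC=C(C)C)cc1`) differs from compound 3 by benzyl in place of tert-butyl on an oxygen next to a carbonyl group and so has benzyl in place of tert-butyl on an oxygen next to a carbonyl group. Compound 1 also carries 2-(benzyloxycarbonyl)ethenyl, and its core differs. What is expected is a number no higher from compound 3 to compound 4 (the limit leaves the size open) and no clear move in either direction. Compound 4 is estimated at 49000 nM (expected range 20000 nM to 60000 nM) in this assay and will probably be reported as a limit.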

Compound 4, half-maximal effective concentration: > 49000 nM
Compound 4: no number, only a limit (the forecaster's own chance of this, stated with the estimate: 80%); the middle value sits exactly at the limit.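

The steps from compounds 1, 2 and 3 to compound 4 cannot be read, as all four compounds share one limit: the limit of > 49000 nM in this assay, at which 4 of the 4 values shown sit.

As far as these compounds go, how these compounds rank, and whether any of these changes alters cytotoxicity, stays open.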